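This account rests on a few compounds, and the source may have more. Where it says the series, first, only, none or still open, it means among the compounds named here.

Compound 1 `COc1cc(C(=O)/C=C/c2ccc(OCCCC(=O)NCCCNCCCCN)cc2)cc(OC)c1OC` and compound 3 `COc1cc(C(=O)/C=C/c2ccc(OCCCC(=O)NCCCCNCCCN)cc2)cc(OC)c1OC` share one core and differ only in that (((3-aminopropyl)amino)methyl in place of (4-aminobutyl)amino on a saturated chain carbon, three bonds along the chain from an amide-type nitrogen). In a functional assay on PC-3 cells (Homo sapiens) for antiproliferative activity, read by MTT assay, with a stated time of 48 h (a higher number here means a weaker inhibitor, a lower number a stronger inhibitor), compound 1 gives a value that is a limit of the assay rather than a number, > 100000 nM. In this assay compound 3 gives 79300 nM. The change makes an at least 1.2-fold lower number from compound 1 to compound 3 (0.10 log units; that floor lies within the scatter), and because one end of that step sits at the limit of > 100000 nM in this assay, at which 1 of the 3 values shown sits, the true size of the step is not known. Compound 2 `COc1ccc(/C=C/C(=O)c2cc(OC)c(OC)c(OC)c2)cc1OCCCC(=O)NCCCNCCCCN` carries a different core, and the difference between the two cores is not broken down here; in this assay compound 2 gives 81000 nM. Compound 4 `COc1ccc(/C=C/C(=O)c2cc(OC)c(OC)c(OC)c2)cc1OCCCC(=O)NCCCCNCCCN` is compound 2 with the same kind of change, (((3-aminopropyl)amino)methyl in place of (4-aminobutyl)amino on a saturated chain carbon, three bonds along the chain from an amide-type nitrogen). A step of about the same small size is expected, a 1.1-fold lower number from compound 2 to compound 4 (0.03 log units; within the scatter), because compound 3 gives 79300 nM within the scatter of compound 2. Compound 4 is therefore estimated at 75000 nM.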

Compound 4, half-maximal inhibitory concentration: 51000 nM
Beside the measured number, compound 4's estimate is 1.5-fold (0.17 log units) above it, and the stated range covers the measured number.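

In this assay, putting ((3-aminopropyl)amino)methyl in place of (4-aminobutyl)amino gives a 1.6-fold lower number from compound 2 to compound 4 (0.20 log units; within the scatter), so on this core the change has no effect that stands clear of the usual variation between repeat measurements. Set beside the step on the core of compound 1, this comparison cannot say whether the change carries over unaltered: the same change on two cores in this assay, an at least 1.2-fold lower number (0.10 log units; that floor lies within the scatter) from compound 1 to compound 3 and a 1.6-fold lower number (0.20 log units; within the scatter) from compound 2 to compound 4; the limit leaves it open whether they differ. Neither step is shown to exceed the scatter, so a real effect of the change is shown on neither core, and the value of compound 1 is a limit: the limit of > 100000 nM in this assay, at which 1 of the 4 values shown sits.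

Going by these compounds, it remains open whether the same change would give a step of similar size on a core bearing a longer chain. On these data alone, it also remains open what would happen with a carboxylic acid in place of the primary amine.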